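Thiazolyl in place of methyl on the exocyclic nitrogen

The compounds below may be only part of what the source reports. "The series", "measured", "known", "first", "only" and "open" are said of these compounds alone.

The series shares the core of compound 1 `CNc1nc2ccccc2c(=O)o1`. In an assay on isolated protein for inhibition of complement C1r subcomponent (Homo sapiens) (on this read-out higher numbers stand for weaker inhibition and lower numbers for stronger inhibition), compound 1 gives > 62500 nM, which is a limit of this assay rather than a number. Compound 1 therefore stands at the limit of > 62500 nM in this assay, at which 1 of the 2 values shown sits. Compound 2 `O=c1oc(Nc2ccccc2I)nc2ccccc12` in this assay gives 3500 nM. Among the compounds with values here, no step between measured compounds that differ in one place is available here, so no measured step size is known.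

Compound 3 `O=c1oc(Nc2nccs2)nc2ccccc12` is not yet measured. It differs from compound 1 by 1,3-thiazol-2-yl in place of methyl on a nitrogen on an aromatic ring, in words 1,3-thiazol-2-yl in place of methyl on a nitrogen on an aromatic ring. The step from compound 1 to compound 3 is expected to go toward stronger inhibition and beyond the scatter, as an at least 7.8-fold lower number from compound 1 to compound 3 (0.89 log units; beyond the scatter). In this assay compound 3 is estimated at 8000 nM, within 1500 nM to 40000 nM. This expectation rests on compound 2, which in this assay gives 3500 nM.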

Compound 3, half-maximal inhibitory concentration: > 62500 nM
Compound 3 gave a limit, no number; the forecaster's own chance of this, stated with the estimate: 20%; middle value at least 7.8-fold (0.89 log units) away from the limit.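

In this assay compound 3 gives > 62500 nM, a limit of the assay and not a number. Compound 1 also stands at a limit, so no step can be read between compound 1 and compound 3. The compounds shown leave open whether 1,3-thiazol-2-yl in place of methyl changes inhibition at all, and by how much.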